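The source may hold more compounds than are shown below. What is called first, only, known or untested is meant among the compounds shown, and "the series" means these compounds.

Working notes on the chalcone-stilbene series.

Compound 1 `CCOc1ccc(C(=O)/C=C/c2c(/C=C/c3ccc(OC)cc3)cc(OC)cc2OC)cc1` and compound 2 `CCCCCCOc1ccc(C(=O)/C=C/c2c(/C=C/c3ccc(OC)cc3)cc(OC)cc2OC)cc1` share the core and differ only in the alkoxy chain on the aryl ketone. In a functional assay on A549 cells (Homo sapiens) for antiproliferative activity, read by MTT assay, with a stated time of 48 h (a higher number here means a weaker inhibitor, a lower number a stronger inhibitor), compound 1 gives 7.5 ug/mL, and compound 2 gives 8.4 ug/mL; the step of a 1.1-fold higher number from compound 1 to compound 2 (0.05 log units; within the scatter) shows that lengthening the chain by a butyl leaves the number where it was, so compound 1 cannot be ranked against compound 2.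

Compound 3 `COc1ccc(/C=C/c2cc(OC)cc(OC)c2/C=C/C(=O)c2ccc(Cl)c(Cl)c2)cc1` changes the aryl ketone itself: 3,4-dichlorophenyl in place of 4-ethoxyphenyl on a carbonyl carbon. Among the compounds with values here, no measured step bears on this part of the molecule; the single step on hand, from compound 1 to compound 2, touches only the chain two bonds from the aromatic oxygen and stayed within the scatter, so it gives no direction for swapping the whole ring substituent. With no evidence either way, the number for compound 3 is expected near that of compound 1, with the step of a 1.1-fold lower number from compound 1 to compound 3 (0.03 log units; within the scatter) estimated as small, and a wide range allowed. Compound 3 is therefore estimated at 7 ug/mL, within 2.5 ug/mL to 20 ug/mL.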

Compound 3, half-maximal inhibitory concentration: 5.9 ug/mL
Compound 3: middle estimate off by 1.2-fold (0.07 log units), on the high side, within the range that was stated.
By their numbers in this assay, from the lowest: compounds 3, 1 and 2 (each within the scatter of the next).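

The step of a 1.3-fold lower number from compound 1 to compound 3 (0.10 log units; within the scatter) in this assay replaces the whole group on the carbonyl carbon, not just the length of the alkoxy chain, so compound 3 cannot be ranked against compound 1. The position therefore takes 3,4-dichlorophenyl in place of 4-ethoxyphenyl, losing the ether oxygen and gaining chlorine, with the number staying within the scatter, which the chain step alone could not show. The data on hand offer no measurement that would account for this result.

On these data alone, whether an amine or a carboxylic acid on this aryl ring would move the number beyond the scatter remains open. Also open, as far as these compounds go, is whether a single chlorine would behave like 3,4-dichlorophenyl, and whether a much longer chain on the aromatic oxygen would leave the number unchanged.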